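Swapping Phenyl for Benzyl on a Shared Core

The source may hold more compounds than are shown below. What is called first, only, known or untested is meant among the compounds shown, and "the series" means these compounds.

Measured compounds:
Compound 1 `Nc1ccccc1NC(=O)c1ccc(Cn2cnc3c(Nc4ccccc4)nc(Cl)nc32)cc1` gives 83.5%.
Compound 2 `Nc1ccccc1NC(=O)c1ccc(Cn2cnc3c(NCc4ccccc4)nc(Cl)nc32)cc1` gives 78.4%.
Compound 3 `Nc1ccccc1NC(=O)/C=C/c1ccc(Cn2cnc3c(Nc4ccccc4)nc(Cl)nc32)cc1` gives 30.9%.

All three numbers come from a functional assay on HCT-116 cells (Homo sapiens) for antiproliferative activity, read by CCK-8 assay, with a stated time of 72 h, tested at 8 uM; on this read-out higher numbers stand for a stronger effect at the one concentration tested and lower numbers for a weaker effect. Compound 2 differs from compound 1 in one place, (benzyl in place of phenyl on a nitrogen on an aromatic ring), and the step of a number 5.1 percentage points lower from compound 1 to compound 2 (within the scatter) shows that this change leaves the read-out essentially where it was. Compound 3 carries a different change on the core of compound 1, (2-((2-aminophenyl)carbamoyl)ethenyl in place of (2-aminophenyl)carbamoyl on an aromatic carbon), and here the step of a number 52.6 percentage points lower from compound 1 to compound 3 (beyond the scatter) is large, so compound 3 stands lowest of the three, beyond the scatter from both others.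

Compound 4 `Nc1ccccc1NC(=O)/C=C/c1ccc(Cn2cnc3c(NCc4ccccc4)nc(Cl)nc32)cc1` has not yet been measured. It differs from compound 3 by benzyl in place of phenyl on a nitrogen on an aromatic ring, and the place around this change is the same, word for word, as for the change from compound 1 to compound 2, so it is the same change made on a different core. Because the earlier step of a number 5.1 percentage points lower from compound 1 to compound 2 (within the scatter) stayed within the scatter, the step for compound 4 is expected to be small as well, estimated at a number 3.9 percentage points lower from compound 3 to compound 4 (within the scatter). Among the compounds with values here, with only one prior example of this change, and none on the core of compound 3, the expectation is uncertain. In this assay compound 4 is therefore estimated at 27%, likely between 12% and 42%.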

Compound 4, a percentage reported as inhibition, at one concentration (the size of the read-out at that concentration, not a potency): 17.4%
Estimate against measurement, compound 4: 9.6 percentage points above; the range from low to high includes it.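

On the core of compound 3, benzyl in place of phenyl on the nitrogen gives a number 13.5 percentage points lower from compound 3 to compound 4 (beyond the scatter) in this assay, a step beyond the scatter, while the same swap on the core of compound 1 stayed within it, yet the two steps themselves do not differ by more than repeated measurements could produce: the same change on two cores in this assay, a number 5.1 percentage points lower (within the scatter) from compound 1 to compound 2 and a number 13.5 percentage points lower (beyond the scatter) from compound 3 to compound 4, 8.4 percentage points apart, within the scatter of two such steps. The other change, 2-((2-aminophenyl)carbamoyl)ethenyl in place of (2-aminophenyl)carbamoyl, gives a number 61 percentage points lower from compound 2 to compound 4 (beyond the scatter) when the nitrogen carries benzyl, and it too keeps its size from one core to the other: the same change on two cores in this assay, a number 52.6 percentage points lower (beyond the scatter) from compound 1 to compound 3 and a number 61 percentage points lower (beyond the scatter) from compound 2 to compound 4, 8.4 percentage points apart, within the scatter of two such steps. Each change therefore carried over between these two cores, but that rests on a single pair of steps per change at one concentration, and it shows neither why the numbers fall nor that the same would hold on any other core.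

The compounds shown leave open how a longer chain such as 2-phenylethyl, or a cyclohexyl ring, would read out on that nitrogen. They also leave open whether a saturated two-carbon chain in place of the ethenyl link would give numbers closer to those of compound 1 or of compound 3.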